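Swapping fluorine for methoxy next to the phenol

The compounds below may be only part of what the source reports. "The series", "measured", "known", "first", "only" and "open" are said of these compounds alone.

Three compounds share one core and have been measured in a functional assay on U-87MG ATCC cells (Homo sapiens) for cytotoxicity, read by MTT assay, with a stated time of 72 h; on this read-out higher numbers stand for weaker inhibition and lower numbers for stronger inhibition:

Compound 1, `CN(C)CCn1cnnc1-c1cc(Oc2ccc(NC(=O)N/N=C/c3ccc(Cl)cc3Cl)cc2F)ccn1`, gives 2330 nM.
Compound 2, `CN(C)CCn1cnnc1-c1cc(Oc2ccc(NC(=O)N/N=C/c3ccc(O)c(Br)c3)cc2F)ccn1`, gives 12400 nM.
Compound 3, `CN(C)CCn1cnnc1-c1cc(Oc2ccc(NC(=O)N/N=C/c3ccc(O)c(F)c3)cc2F)ccn1`, gives only a limit of the assay, > 100000 nM.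

Compound 3 therefore stands at the weak end of the three; its number is not known, only that it sits at the limit (the limit of > 100000 nM in this assay, at which 1 of the 3 values shown sits). The change from compound 1 to compound 3 was an at least 42-fold higher number from compound 1 to compound 3 (1.63 log units; beyond the scatter), and from compound 2 to compound 3 it was an at least 8.0-fold higher number from compound 2 to compound 3 (0.90 log units; beyond the scatter), so on this hydroxyphenyl arm the small fluoro substituent goes with the weakest result, while the larger bromo of compound 2 keeps more activity.

Compound 4, `COc1cc(/C=N/NC(=O)Nc2ccc(Oc3ccnc(-c4nncn4CCN(C)C)c3)c(F)c2)ccc1O`, differs from compound 3 by methoxy in place of fluoro on an aromatic carbon. Going by the values given here, the only measured step that bears on it is the bromo-to-fluoro step, which was large. Methoxy is bigger than fluoro and closer in bulk to bromo, so compound 4 is expected to recover part of that loss: an estimated step of an at least 3.3-fold lower number from compound 3 to compound 4 (0.52 log units; beyond the scatter) in this assay, towards stronger inhibition. Compound 4 is thus expected at about 30000 nM, in a range from 8000 nM to 100000 nM.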

Compound 4, half-maximal inhibitory concentration: > 100000 nM
Compound 4: only a limit was reported; the forecaster's own chance of this, stated with the estimate: 30%; at least 3.3-fold (0.52 log units) between middle value and limit.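

In this assay compound 4 gives > 100000 nM, which is a limit of the assay and not a number, so methoxy at this place, ortho to a hydroxy group, does not keep the measurable activity seen with bromo. Two steps show how much is lost: there is an at least 8.0-fold higher number from compound 2 to compound 4 (0.90 log units; beyond the scatter), and with the 4-hydroxy-3-methoxyphenyl group in place of 2,4-dichlorophenyl there is an at least 42-fold higher number from compound 1 to compound 4 (1.63 log units; beyond the scatter). Among the three hydroxyphenyl compounds, compound 2 with bromo is now the only one with a readable number, while the fluoro of compound 3 and the methoxy of compound 4 both end at the same ceiling: the limit of > 100000 nM in this assay, at which 2 of the 4 values shown sit.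

The step from compound 3 to compound 4 cannot be read, so any difference between fluoro and methoxy at this place remains hidden. As far as these compounds go, it also remains open whether bromo is alone in giving a readable number here, or whether an iodo, a methyl or an amino group at the same place would do so too.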